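Second methyl added to a sulfonamide phenol

The source may report more compounds than this note shows. Statements on the series, on what has been measured and on what is new or still open speak of the compounds shown alone.

Measured compounds:
- compound 1 `Cc1ccc(O)c(NS(=O)(=O)c2ccc(C(C)(C)C)cc2)c1`: 4090 nM
- compound 2 `CC(C)(C)c1ccc(S(=O)(=O)Nc2cc(Cl)ccc2O)cc1`: 800 nM

In an assay on HEK293 cells for inhibition of 17-beta-hydroxysteroid dehydrogenase type 2 (Homo sapiens), read by scintillation counting, with a stated time of 10 min, in the presence of a further agent that is not named here (a higher number here means a weaker inhibitor, a lower number a stronger inhibitor), compound 1 gives 4090 nM, the highest of the two numbers; the nearest, compound 2, gives 800 nM. Among the measured compounds shown here, the one measured step, a 5.1-fold lower number from compound 1 to compound 2 (0.71 log units; beyond the scatter), is a chloro in place of a methyl on an aromatic carbon, and it is beyond the scatter.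

Compound 3 `Cc1cc(C)c(O)c(NS(=O)(=O)c2ccc(C(C)(C)C)cc2)c1` differs from compound 1 by methyl in place of hydrogen on an aromatic carbon, on an aromatic carbon of a six-membered aromatic ring of carbon only, ortho to a hydroxy group, meta to a large group and meta to a methyl group. For the measured compounds named here, no measured step adds a group at that position, so the step from compound 1 to compound 2 informs only indirectly. A step within the scatter in this assay, in either direction, is therefore expected, written as a 1.4-fold lower number from compound 1 to compound 3 (0.13 log units; within the scatter). The estimate for compound 3 is 3000 nM, with a range from 900 nM to 10000 nM.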

Compound 3, half-maximal inhibitory concentration: 5190 nM
Beside the measured number, compound 3's estimate is 1.7-fold (0.24 log units) below it, within the range that was stated.
By their numbers in this assay, from the lowest: compound 2; then compounds 1 and 3 (each within the scatter of the next).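

In this assay, methyl in place of hydrogen on the aromatic carbon ortho to a hydroxy group gives a 1.3-fold higher number from compound 1 to compound 3 (0.10 log units; within the scatter) and so shows that a methyl can stand on this carbon without a change that can be told from the scatter. The earlier step, a 5.1-fold lower number from compound 1 to compound 2 (0.71 log units; beyond the scatter) for a chloro in place of a methyl on a different aromatic carbon, showed that the number can respond to a change on this aromatic ring but said nothing about this carbon. No measurement at hand bears on the reason for this result.

The compounds shown leave open whether a methoxy group or an amine on this same carbon would also stay within the scatter of compound 1. Among the compounds shown here, they also leave open whether a chloro here would give a step like the one seen for compound 2.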